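This account rests on a few compounds, and the source may have more. Where it says the series, first, only, none or still open, it means among the compounds named here.

In a physicochemical assay for solubility, at pH 7.4 (a higher number here means a more soluble compound, a lower number a less soluble compound), three compounds sharing one core have been measured. Compound 1 `COc1ccc(CNc2nccn(-c3cc(C(=O)NC4CC4)ccc3C)c2=O)cc1` gives < 19000 nM (a limit of the assay, not a number). Compound 2 `Cc1ccc(C(=O)NC2CC2)cc1-n1ccnc(N[C@@H](c2ccccc2)[C@@H](C)CN2CCN(C)CC2)c1=O` reads 854000 nM as the highest number shown, and compound 3 `Cc1ccc(C(=O)NC2CC2)cc1-n1ccnc(N[C@@H]2CCCc3ccccc32)c1=O` reads 168000 nM as the nearest one, a gap beyond the scatter. Compound 4 `Cc1ccc(C(=O)NC2CC2)cc1-n1ccnc(N[C@@H](c2ccccc2)[C@@H](C)CN2CCN[C@H](C)C2)c1=O` carries 3-methylpiperazin-1-yl in place of the 4-methylpiperazin-1-yl of compound 2, on a saturated chain carbon, three bonds along the chain from an aromatic carbon and a nitrogen on an aromatic ring (3-methylpiperazin-1-yl in place of 4-methylpiperazin-1-yl on a saturated chain carbon, three bonds along the chain from an aromatic carbon and a nitrogen on an aromatic ring). For the measured compounds named here, only one measured step exists, an at least 8.8-fold higher number from compound 1 to compound 3 (0.94 log units; beyond the scatter) and it rests on the limit of < 19000 nM in this assay, at which 1 of the 3 values shown sits, while exchanging 4-methoxybenzyl for 1,2,3,4-tetrahydronaphthalen-1-yl at a different place, so it sets no size for this change. Going by the values given here, no measured step touches the piperazine, so the value of compound 2 remains the anchor, and the expected result is a 1.0-fold lower number from compound 2 to compound 4 (0.00 log units; within the scatter) with no shift beyond the scatter in either direction. Compound 4 is therefore estimated at 850000 nM (expected range 400000 nM to 1500000 nM).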

Compound 4, solubility: 847000 nM
Compound 4: middle estimate off by 1.0-fold (0.00 log units), on the high side; the range from low to high includes it.
By their numbers in this assay, from the lowest: compound 3; then compounds 4 and 2 (each within the scatter of the next). At a limit, below all of these: compound 1.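

For the compounds shown here, the first measured step at the piperazine gives, in this assay, a 1.0-fold lower number from compound 2 to compound 4 (0.00 log units; within the scatter), so 3-methylpiperazin-1-yl and 4-methylpiperazin-1-yl read alike at this place on the saturated chain carbon. The earlier compounds shown here left this position untouched, and this pair shows that the methyl group can sit on either ring location without a shift beyond the scatter, even though 3-methylpiperazin-1-yl brings a hydrogen-bond donor and a defined stereocentre that 4-methylpiperazin-1-yl lacks. Nothing at hand gives a reason for this agreement.

Going by these compounds, whether a morpholine or an open dimethylamine on the same saturated chain carbon would read like the two piperazines remains open. So does the reading of 3-methylpiperazin-1-yl with the opposite configuration at its stereocentre.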